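From hydroxycarbamoyl to cyano on the side chain

The compounds below may be only part of what the source reports. "The series", "measured", "known", "first", "only" and "open" are said of these compounds alone.

Measured in an ADME assay on Huh-7 cells (Homo sapiens) for cytotoxicity, with a stated time of 72 h; on this read-out lower numbers stand for higher toxicity in this test and higher numbers for lower toxicity in this test:
Compound 1 `CC(C)CCn1nc(-c2cccs2)c(O)c(C2=NS(=O)(=O)c3cc(OC(C)C(N)=O)ccc3N2)c1=O` gives 68000 nM
Compound 2 `CC(C)CCn1nc(-c2cccs2)c(O)c(C2=NS(=O)(=O)c3cc(OCC(=O)NO)ccc3N2)c1=O` gives > 33000 nM (a limit, not a number)

Compound 2 stands only at a limit, > 33000 nM. Compound 3 `CC(C)CCn1nc(-c2cccs2)c(O)c(C2=NS(=O)(=O)c3cc(OCC#N)ccc3N2)c1=O` carries cyano in place of hydroxycarbamoyl on a saturated chain carbon bound to an oxygen on an aromatic ring. Going by the values given here, the one measured step on this side chain is a step that the limit leaves unreadable from compound 1 to compound 2, so it offers no size to carry over. Among the compounds with values here, compound 1 holds the only number, 68000 nM, and that number anchors the expectation. The expected step is a step that the limit leaves unreadable from compound 2 to compound 3, with no change beyond the scatter foreseen in this assay. For compound 3 the estimated value is 50000 nM, with an expected range from 20000 nM to 110000 nM.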

Compound 3, half-maximal cytotoxic concentration: > 33000 nM
Compound 3 ended at the assay's limit (the forecaster's own chance of this, stated with the estimate: 50%); the middle value is on the limit's open side.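

No new step can be read among compound 1, compound 2 and compound 3, because two of these values are limits and not numbers: the limit of > 33000 nM in this assay, at which 2 of the 3 values shown sit.

The compounds shown leave open how compound 2 and compound 3 compare with each other and with compound 1.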